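Permeability notes: removing the pyridinyl amide from compound 1

The source may hold more compounds than are shown below. What is called first, only, known or untested is meant among the compounds shown, and "the series" means these compounds.

For the measured compounds named here, compound 1 `CCCCc1nc(=O)c(S(=O)(=O)c2ccc(-c3ccnc(NC(=O)C4CC4)c3)cc2)c(O)n1-c1c(OC)cccc1OC` is the only member of the series with a number in an ADME assay for permeability, using PAMPA, at pH 7.4; a higher number here means that the compound crosses the layer faster, a lower number that the compound crosses the layer more slowly: compound 1 gives 11 nm/s. Compound 2 `CCCCc1[nH]c(=O)c(S(=O)(=O)c2ccc(-c3ccc(F)nc3)cc2)c(O)c1-c1c(OC)cccc1OC` shares the sulfone and the dimethoxyphenyl group but has no result; for compound 2 the entry reads "not determined" (no result reported). Going by the values given here, no step between two measured compounds is therefore available.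

Compound 3 `CCCCc1nc(=O)c(S(=O)(=O)c2ccccc2)c(O)n1-c1c(OC)cccc1OC` differs from compound 1 by hydrogen in place of 2-((cyclopropylcarbonyl)amino)pyridin-4-yl on an aromatic carbon, the change sitting on an aromatic carbon of a six-membered aromatic ring of carbon only, para to a large group. The group that leaves is 2-((cyclopropylcarbonyl)amino)pyridin-4-yl, and only a hydrogen atom enters.

With nothing else measured, the expectation rests on compound 1 alone: the step from compound 1 to compound 3 is expected to be a rise in this assay, of about a 2.7-fold higher number from compound 1 to compound 3 (0.44 log units; beyond the scatter), beyond the scatter but not large. Compound 3 is accordingly estimated at 30 nm/s, within 8 nm/s to 110 nm/s.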

Compound 3, apparent permeability: 1.5 nm/s
Estimate against measurement, compound 3: 20-fold (1.30 log units) above; measured number below the stated range.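

In this assay, for the compounds shown here, this pair gives the first readable step: a 7.3-fold lower number from compound 1 to compound 3 (0.87 log units; beyond the scatter) on hydrogen replacing 2-((cyclopropylcarbonyl)amino)pyridin-4-yl. At this aromatic carbon, para to a large group, the compound that keeps the substituent therefore carries the higher number, and the bare ring does not move the read-out upward. Nothing measured here accounts for the direction of this step.

A single pair cannot show which part of the departing group goes with the difference, since the amide and the pyridin-4-yl ring leave together. Going by these compounds, it also remains open where a simple amine, a carboxylic acid or a methoxy group at this aromatic carbon would fall relative to compound 1 and compound 3.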